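The source may report more compounds than this note shows. Statements on the series, on what has been measured and on what is new or still open speak of the compounds shown alone.

Of the compounds shown here, two built on one shared core have numbers so far in an ADME assay for cytotoxicity, read by propidium iodide staining; a lower number here means that less compound is tolerated, a higher number that more compound is tolerated. There, compound 1 `CC(C)(C)n1nc(Cc2ccc(Cl)cc2)c2ccccc2c1=O` gives 72100 nM and compound 2 `O=c1c2ccccc2c(Cc2ccc(Cl)cc2)nn1-c1ccc([N+](=O)[O-])cc1` gives 96300 nM. Going by the values given here, with only these two values available, compound 2 stands level with its sole neighbour, since repeat measurements of one compound could differ this much.

Compound 3 `O=c1c2ccccc2c(Cc2ccc(Cl)cc2)nn1-c1ccc(Br)cc1` has not yet been measured. It differs from compound 2 in one place: bromo in place of nitro on an aromatic carbon. In words, this is bromo in place of nitro on an aromatic carbon, so 4-nitrophenyl becomes 4-bromophenyl.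

Among the compounds with values here, no measured pair makes this exact swap, and no bromo compound has a number yet. The nearest evidence is a change of the whole group on the aromatic nitrogen, tert-butyl to 4-nitrophenyl, which gave only a 1.3-fold higher number from compound 1 to compound 2 (0.13 log units; within the scatter). One step is thin evidence, but it offers no reason to expect a real shift in this assay, in either direction.

The expected change is small, a 1.2-fold lower number from compound 2 to compound 3 (0.08 log units; within the scatter), and this is only an estimate. For compound 3 the estimated value is 80000 nM, with an expected range from 40000 nM to 150000 nM.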

Compound 3, half-maximal cytotoxic concentration: 91800 nM
For compound 3 the middle estimate is 1.1-fold (0.06 log units) below the measured one, within the range that was stated.
By their numbers in this assay, from the lowest: compounds 1, 3 and 2 (each within the scatter of the next).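

At this place on the ring, para to a large group, bromo in place of nitro gives a 1.0-fold lower number from compound 2 to compound 3 (0.02 log units; within the scatter) in this assay. A single bromine atom can therefore replace the 3 heavy atoms of nitro and its 2 hydrogen-bond acceptors with no readable difference in this assay. On the aromatic nitrogen, the swap of tert-butyl for 4-bromophenyl gives a 1.3-fold higher number from compound 1 to compound 3 (0.10 log units; within the scatter) and so, like the swap for 4-nitrophenyl, does not separate an aromatic ring from tert-butyl at this position. No measurement offered here accounts for why these numbers stay so close.

From the compounds shown here alone, whether an amine or a carboxylic acid on the same ring carbon, or a longer chain on the aromatic nitrogen, would shift the number beyond the scatter remains open. The rest of the shared core is identical in all three compounds, so how much it contributes to the tolerated concentration cannot be told from these results.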